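The compounds below may be only part of what the source reports. "The series", "measured", "known", "first", "only" and "open" are said of these compounds alone.

Compound 2 `Cn1nc(-c2ccc(OCC3CC4(CNC4)C3)c(F)c2)c2cnc(N)nc21` holds the lowest number of the two measured compounds in an assay on THP-1 cells for antagonist activity at Toll-like receptor 8 (Homo sapiens) (on this read-out higher numbers stand for weaker inhibition and lower numbers for stronger inhibition), giving 10 nM, while compound 1 `Cn1nc(-c2ccc(OCC3CCNCC3)c(F)c2)c2cnc(N)nc21` gives 60 nM in this assay. Going by the values given here, the single measured step, a 6.0-fold lower number from compound 1 to compound 2 (0.78 log units; beyond the scatter), was modest. Compound 3 `Cn1nc(-c2ccc(OCCCC3CCNCC3)c(F)c2)c2cnc(N)nc21` goes back to a six-membered ring with one hetero atom: a group of 8 heavy atoms (7 carbon, 1 nitrogen; one six-membered non-aromatic ring with 1 hetero atom) in place of a group of 7 heavy atoms (6 carbon, 1 nitrogen; one four-membered non-aromatic ring of carbon only, one four-membered non-aromatic ring with 1 hetero atom), on a saturated chain carbon bound to an oxygen on an aromatic ring. That measured step is the one that bears on this change, since compound 3 carries a 2-(piperidin-4-yl)ethyl group, a homologue of the group in compound 1, and the pair of four-membered rings that compound 2 carries is given up. Because the step of a 6.0-fold lower number from compound 1 to compound 2 (0.78 log units; beyond the scatter) ran the other way, the number for compound 3 is expected to move back toward that of compound 1, with a change a 5.0-fold higher number from compound 2 to compound 3 (0.70 log units; beyond the scatter) expected to lie beyond the scatter. Compound 3 is estimated at 50 nM in this assay, with a likely range from 15 nM to 200 nM.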

Compound 3, half-maximal inhibitory concentration: 26 nM
Compound 3: middle estimate off by 1.9-fold (0.28 log units), on the high side, within the range that was stated.
By their numbers in this assay, from the lowest: compound 2; then compound 3; then compound 1.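

In this assay, 2-(piperidin-4-yl)ethyl in place of piperidin-4-yl gives a 2.3-fold lower number from compound 1 to compound 3 (0.36 log units; beyond the scatter), so at this position a six-membered ring with one hetero atom can carry a lower number than the one first seen, and the number responds to the group's chain as well as to its ring. Giving up the pair of four-membered rings for this group still leaves a 2.6-fold higher number from compound 2 to compound 3 (0.41 log units; beyond the scatter), which shows that the longer piperidine group recovers only part of the gap and that the spiro-linked four-membered rings remain ahead. Nothing available explains either step.

On these data alone, it remains open whether a 3-(piperidin-4-yl)propyl group would lower the number further or reverse the trend. As far as these compounds go, it is also open whether a single azetidine ring or an open-chain amine on this carbon would match the pair of four-membered rings.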